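Removing the Aromatic Chloro Group: What to Expect for Compound 4

The source may hold more compounds than are shown below. What is called first, only, known or untested is meant among the compounds shown, and "the series" means these compounds.

Three compounds have been measured in a functional assay on the whole organism (strain Swiss) with Mus musculus as the target, in the maximal electroshock model, with a stated time of 2 h, at a dose of 100 mg/kg by the intraperitoneal route; a lower number here means a weaker effect, a higher number a stronger effect of the compound at the dose given:

Compound 1 `CCC(C(=O)N1CCN(c2cccc(C(F)(F)F)c2)CC1)N1C(=O)CCC1=O` gives 0%.
Compound 2 `CCC(C(=O)N1CCN(c2cccc(C)c2)CC1)N1C(=O)CCC1=O` gives 0%.
Compound 3 `CCC(C(=O)N1CCN(c2cccc(Cl)c2)CC1)N1C(=O)CCC1=O` gives 0%.

Compound 3 stands level with compounds 1 and 2. The three steps that connect the measured compounds, no change at the digits printed from compound 1 to compound 2 (within the scatter), no change at the digits printed from compound 1 to compound 3 (within the scatter) and no change at the digits printed from compound 2 to compound 3 (within the scatter), all lie within the usual scatter of this kind of measurement. Each of these steps exchanges one substituent for another at the same aromatic carbon of the shared core, and none of them moved the read-out.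

Compound 4 `CCC(C(=O)N1CCN(c2ccccc2)CC1)N1C(=O)CCC1=O` differs from compound 3 by hydrogen in place of chloro on an aromatic carbon. This change goes one step further than the measured ones: rather than swapping one substituent for another, it removes the substituent at that aromatic carbon altogether. Among the measured compounds shown here, no measured step removes a group entirely, so the expectation rests only on the observation that three different groups at this carbon all gave the same read-out. On that basis, no step beyond the scatter is expected in this assay for compound 4, and since the read-out cannot fall below zero, the expected step is no change at the digits printed from compound 3 to compound 4 (within the scatter). The estimate for compound 4 is 0%, with a range from 0% to 10%.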

Compound 4, a percentage reported as activity, at one dose (the size of the read-out at that dose, not a potency): 0%
Beside the measured number, compound 4's estimate shows no gap at the digits printed; measured number inside the range.
By their numbers in this assay, from the lowest: compounds 1, 2, 3 and 4 (each within the scatter of the next).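

Removing the group outright, the change from 3-chlorophenyl to phenyl, leaves this assay where it was: the step reads no change at the digits printed from compound 3 to compound 4 (within the scatter) and the two other comparisons read no change at the digits printed from compound 2 to compound 4 (within the scatter) and no change at the digits printed from compound 1 to compound 4 (within the scatter) as well. The earlier compounds shown here only showed one substituent traded for another at this aromatic carbon, whereas these steps show that a bare hydrogen there gives the same read-out as chloro, methyl or trifluoromethyl. All four compounds sit at the bottom of the scale, so these steps cannot show whether this position matters for the effect, and no supporting data bear on the flat result.

As far as these compounds go, it remains open whether an amine, a carboxylic acid or a longer chain at this aromatic carbon would lift the read-out above the bottom of the scale. From the compounds shown here alone, it is also open whether a change elsewhere on the shared core would give a measurable effect against which substituents at this carbon could be compared.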